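Bromine Leaves, Three Methoxy Groups Arrive on the Pyrazoline Arm

The source may report more compounds than this note shows. Statements on the series, on what has been measured and on what is new or still open speak of the compounds shown alone.

Of the compounds shown here, three sharing one core have been tested in a functional assay on A549 cells (Homo sapiens) for inhibition, read by sulforhodamine B assay, tested at 10 uM; a lower number here means less inhibition of growth, a higher number more inhibition of growth at the concentration tested. Compound 1 `CC(=O)N1N=C(c2ccc(OCc3cn(Cc4ccc([N+](=O)[O-])cc4)nn3)cc2)CC1c1ccccc1` gives 15%. Compound 2 `COc1cc(C2CC(c3ccc(OCc4cn(Cc5ccc([N+](=O)[O-])cc5)nn4)cc3)=NN2C(C)=O)ccc1Oc1cn(Cc2ccc([N+](=O)[O-])cc2)nn1` gives 29%. Compound 3 `COc1cc(C2CC(c3ccc(Br)cc3)=NN2C(C)=O)ccc1OCc1cn(Cc2ccc([N+](=O)[O-])cc2)nn1` gives 0%, the lowest of the three numbers: compound 1 lies above it beyond the scatter, and compound 2 lies further above it, also beyond the scatter. No pair among these three differs in just one place, so no single step can be read from them.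

Compound 4 `COc1cc(C2CC(c3cc(OC)c(OC)c(OC)c3)=NN2C(C)=O)ccc1OCc1cn(Cc2ccc([N+](=O)[O-])cc2)nn1` differs from compound 3 in one place: 3,4,5-trimethoxyphenyl in place of 4-bromophenyl on a carbon with a double bond to nitrogen. Because compound 3 gives 0%, the step can hardly go downward. Compound 1 with 15% and compound 2 with 29% show that members of this series can reach modest inhibition in this assay. The step is therefore expected to be upward but modest, and compound 4 is estimated at 15%, between 0% and 40%, a change from compound 3 to compound 4 of a number 15 percentage points higher from compound 3 to compound 4 (beyond the scatter).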

Compound 4, percent growth inhibition at one concentration: 68%
Estimate against measurement, compound 4: 53 percentage points below; the whole stated range lies below it.
By their numbers in this assay, from the lowest: compound 3; then compound 1; then compound 2; then compound 4.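

Among the compounds shown here, the carbon with a double bond to nitrogen, two ring bonds from the ring atom that bears an acetyl group, turns out to be a place that matters in this assay: 3,4,5-trimethoxyphenyl in place of 4-bromophenyl gives a number 68 percentage points higher from compound 3 to compound 4 (beyond the scatter), the first step that can be read at all. Everything else in the molecule stays the same across this step, so the whole difference belongs to this one exchange of aryl groups. Nothing available explains why the step is so large.

The compounds shown leave open whether the full 3,4,5-trimethoxyphenyl group is needed, or whether a phenyl ring carrying a single methoxy group, a dimethylamino group or a carboxylic acid would serve at this place. They also leave open whether the same exchange would give a step of similar size with a different group on the other aryl ring.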